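Swapping the pyridinyl for methoxy on the amide nitrogen

A few compounds are considered here, and "the series" means these few. Any claim that something is new, unique, unknown or untested is made for them only; others in the source may bear on it.

Measured compounds:
compound 1 `Cc1ccc(OCC(=O)N(Cc2cccs2)c2ccn[nH]2)cc1`: 0.2 nM
compound 2 `Cc1ccc(OCC(=O)N(Cc2cccs2)C2CC2)cc1`: 8 nM
compound 3 `Cc1ccc(OCC(=O)N(Cc2cccs2)c2ccncc2)cc1`: 52 nM

In an assay on HEK293 cells for agonist activity at transient receptor potential cation channel subfamily M member 8 (Homo sapiens), read by fluorescence and calcium flux, with a stated time of 15 min (a higher number here means that more compound is needed for the effect, a lower number that less compound is needed), compound 3 gives 52 nM, the highest of the three numbers; the nearest is compound 2 with 8 nM, and the furthest is compound 1 with 0.2 nM. Compound 4 `CON(Cc1cccs1)C(=O)COc1ccc(C)cc1` differs from compound 3 in one place: methoxy in place of pyridin-4-yl on an amide-type nitrogen. The step that bears on this is a 6.5-fold higher number from compound 2 to compound 3 (0.81 log units; beyond the scatter), in which a group without a ring was exchanged for the pyridin-4-yl; here the pyridin-4-yl leaves again for a small group without a ring. A modest step towards a lower number in this assay is therefore expected, though the methoxy is not the cyclopropyl, so the size is uncertain. For compound 4 the expected value is 20 nM, within 3 nM to 150 nM, which is estimated as a 2.6-fold lower number from compound 3 to compound 4 (0.41 log units; beyond the scatter).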

Compound 4, half-maximal effective concentration: 10 nM
Beside the measured number, compound 4's estimate is 2.0-fold (0.30 log units) above it; the range from low to high includes it.
By their numbers in this assay, from the lowest: compound 1; then compounds 2 and 4 (each within the scatter of the next); then compound 3.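

Removing the pyridin-4-yl ring gives a 5.2-fold lower number from compound 3 to compound 4 (0.72 log units; beyond the scatter), so a low number at this amide-type nitrogen does not require a ring. Methoxy and cyclopropyl cannot be told apart, since a 1.3-fold higher number from compound 2 to compound 4 (0.10 log units; within the scatter) is a difference that stays within the scatter. The small group still falls well short of the 1H-pyrazol-5-yl, with a 50-fold higher number from compound 1 to compound 4 (1.70 log units; beyond the scatter), so one aromatic ring here outperforms it while another does not.

No measurement shown explains these differences. On these data alone, whether a longer ethoxy chain or an amine such as dimethylamino would keep the number low remains open.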